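A Methyl Replaces Methoxy on the Aryl Ketone

The compounds below may be only part of what the source reports. "The series", "measured", "known", "first", "only" and "open" are said of these compounds alone.

Going by the values given here, compound 2 `COc1ccc(C(=O)CSc2nnc(-c3cc(OC)c(OC)c(OC)c3)n2N2C(=O)c3ccccc3C2=O)cc1` gives 30000 nM in a functional assay on A549 cells (Homo sapiens) for cytotoxicity, read by MTT assay, with a stated time of 48 h (on this read-out higher numbers stand for weaker inhibition and lower numbers for stronger inhibition), the only number among the values shown. Compound 1 `COc1cc(-c2nnc(SCC(=O)c3ccccc3)n2N2C(=O)c3ccccc3C2=O)cc(OC)c1OC` reports only a limit in this assay, > 200000 nM. Compound 3 `COc1cc(-c2nnc(SCC(=O)c3ccccc3C)n2N2C(=O)c3ccccc3C2=O)cc(OC)c1OC` differs from compound 2 by 2-methylphenyl in place of 4-methoxyphenyl on a carbonyl carbon. Among the compounds with values here, one measured step bears on this change: an at least 6.6-fold lower number from compound 1 to compound 2 (0.82 log units; beyond the scatter); compound 3 removes that same methoxy and brings in a methyl. An upward step is therefore expected, a 5.0-fold higher number from compound 2 to compound 3 (0.70 log units; beyond the scatter). The limit of > 200000 nM in this assay, at which 1 of the 2 values shown sits, is within reach. Compound 3 is estimated at 150000 nM, between 40000 nM and 400000 nM.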

Compound 3, half-maximal inhibitory concentration: 144000 nM
Beside the measured number, compound 3's estimate is 1.0-fold (0.02 log units) above it; measured number inside the range.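

On a carbonyl carbon, 2-methylphenyl in place of 4-methoxyphenyl brings a 4.8-fold higher number from compound 2 to compound 3 (0.68 log units; beyond the scatter) in this assay and so the lower number of compound 2 is not held once the methoxy gives way to a methyl. Methyl in place of hydrogen brings an at least 1.3-fold lower number from compound 1 to compound 3 (0.14 log units; that floor lies within the scatter) and that change stays unranked. Compound 1 remains a limit and no more: the limit of > 200000 nM in this assay, at which 1 of the 3 values shown sits.

Going by these compounds, whether an amine or a carboxylic acid in the place of that methoxy would follow the methoxy or the methyl stays open.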